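One More Oxygen on the Aromatic Ring of Compound 3

The source may hold more compounds than are shown below. What is called first, only, known or untested is meant among the compounds shown, and "the series" means these compounds.

Three compounds sharing one core were examined in an ADME assay on microsomes from liver (Homo sapiens) for metabolic stability; a lower number here means slower removal, a higher number faster removal of the compound. Compound 1 `COc1cc(F)ccc1-c1ccnc2[nH]c(C3CCN(CC(=O)N(C)C)CC3)cc12` gives 14 uL/min, and compound 2 `CC(C)n1cc(-c2ccnc3[nH]c(C4CCN(CC(=O)N(C)C)CC4)cc23)cnc1=O` gives 24 uL/min; the step of a 1.7-fold higher number from compound 1 to compound 2 (0.23 log units; within the scatter) stays within the scatter. Compound 3 `CCn1cc(-c2ccnc3[nH]c(C4CCN(CC(=O)N(C)C)CC4)cc23)ccc1=O` sits at the limit of the assay, reported as < 3 uL/min, so only a bound is known for it. The steps into compound 3 were an at least 4.6-fold lower number from compound 1 to compound 3 (0.66 log units; beyond the scatter) and an at least 8.0-fold lower number from compound 2 to compound 3 (0.90 log units; beyond the scatter), both beyond the scatter, and both reach the limit at which one of the three values sits (the limit of < 3 uL/min in this assay, at which 1 of the 3 values shown sits). Compound 4 `COc1cc(=O)n(C)cc1-c1ccnc2[nH]c(C3CCN(CC(=O)N(C)C)CC3)cc12` differs from compound 3 in one place: a group of 10 heavy atoms (7 carbon, 1 nitrogen, 2 oxygen; one six-membered aromatic ring with 1 hetero atom) in place of a group of 9 heavy atoms (7 carbon, 1 nitrogen, 1 oxygen; one six-membered aromatic ring with 1 hetero atom), on an aromatic carbon. For the measured compounds named here, no measured step runs onward from compound 3, and none alters this same group by one added oxygen, so the two steps ending in compound 3 show only that the group compound 3 carries goes with slow removal. The step of an at least 1.3-fold higher number from compound 3 to compound 4 (0.12 log units; that floor lies within the scatter) is expected to stay within the scatter. Compound 4 is therefore estimated at 4 uL/min, with a range of 2 uL/min to 10 uL/min, and the assay may again report only its limit.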

Compound 4, intrinsic clearance in a liver preparation (reported as CLH), per the amount of preparation that the assay uses: < 3 uL/min
Compound 4 ended at the assay's limit; the forecaster's own chance of this, stated with the estimate: 45%; middle value at least 1.3-fold (0.12 log units) away from the limit.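

In this assay compound 4 gives < 3 uL/min, which is a limit of the assay and not a number. On this aromatic carbon, opposite the ring nitrogen, the group carrying the second oxygen goes with slow removal just as the group of compound 3 does, with an at least 8.0-fold lower number from compound 2 to compound 4 (0.90 log units; beyond the scatter) and an at least 4.6-fold lower number from compound 1 to compound 4 (0.66 log units; beyond the scatter), both beyond the scatter. The step between compound 3 and compound 4 cannot be read, since both values are limits: the limit of < 3 uL/min in this assay, at which 2 of the 4 values shown sit.

Going by these compounds, how far removal of compound 3 and compound 4 lies past that limit remains open, so any difference between their two groups stays hidden. Also open, on these data alone, is whether an amine or a carboxylic acid on this ring, in place of the second oxygen, would keep removal at the limit.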